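Aminophenyl Enone Borinate: Estimating Cytotoxicity of Compound 4

The source may hold more compounds than are shown below. What is called first, only, known or untested is meant among the compounds shown, and "the series" means these compounds.

Measured compounds:
compound 1 `O=C(/C=C/c1ccc2c(c1)B(O)OC2)c1ccc(F)cc1` 1400 nM
compound 2 `O=C(/C=C/c1ccc2c(c1)B(O)OC2)c1ccc(OCc2ccccc2)cc1` 6000 nM
compound 3 `O=C(/C=C/c1ccc2c(c1)B(O)OC2)c1ccc(C(F)(F)F)cc1` 3700 nM

In a functional assay on SK-OV-3 cells (Homo sapiens) for cytotoxicity, read by MTT assay, with a stated time of 48 h (a higher number here means a weaker inhibitor, a lower number a stronger inhibitor), compound 1 gives the lowest of the three numbers. Replacing its fluoro with benzyloxy gave a 4.3-fold higher number from compound 1 to compound 2 (0.63 log units; beyond the scatter), and with trifluoromethyl gave a 2.6-fold higher number from compound 1 to compound 3 (0.42 log units; beyond the scatter); both changes on the aryl ring moved the number up by a modest amount. The unmeasured compound 4 `Nc1cccc(C(=O)/C=C/c2ccc3c(c2)B(O)OC3)c1` differs from compound 1 by 3-aminophenyl in place of 4-fluorophenyl on a carbonyl carbon. Neither measured step involves an amino group or a hydrogen-bond donor, so they bear on compound 4 only loosely: they show that the two departures from fluoro tried so far each raised the number beyond the scatter. On that basis the step from compound 1 to compound 4 is expected to be a modest rise, a 1.8-fold higher number from compound 1 to compound 4 (0.25 log units; within the scatter), though the range is kept wide. Compound 4 is therefore estimated at 2500 nM, between 1000 nM and 7000 nM.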

Compound 4, half-maximal inhibitory concentration: 7400 nM
Estimate against measurement, compound 4: 3.0-fold (0.47 log units) below; the whole stated range lies below it.
By their numbers in this assay, from the lowest: compound 1; then compounds 3, 2 and 4 (each within the scatter of the next).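

In this assay, exchanging the whole aryl group on the carbonyl carbon gave a 5.3-fold higher number from compound 1 to compound 4 (0.72 log units; beyond the scatter), and this time the entering 3-aminophenyl carries a hydrogen-bond donor and a hydrogen-bond acceptor that the leaving 4-fluorophenyl lacks. All three departures from compound 1 now raise the number beyond the scatter, so compound 1 stands as the strongest of the four, and the change to an amino-bearing aryl group offers no gain over fluoro. Nothing available explains why the number rose with this change.

Going by these compounds, whether the rise belongs to the amino group itself or to where it stands on the ring stays open, as the two change together in compound 4. On these data alone, how a hydroxyl group or a carboxylic acid on that aryl ring would read in this assay also remains open.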